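From Cyclohexyl to Isopropyl on an Amine Nitrogen

This account rests on a few compounds, and the source may have more. Where it says the series, first, only, none or still open, it means among the compounds named here.

In a functional assay for inhibition, with Rattus norvegicus as the target (a higher number here means a weaker inhibitor, a lower number a stronger inhibitor), compound 1 (`CC(N/C(=C\[N+](=O)[O-])Nc1cccnc1)C(C)(C)C`) reads 31.6 nM and compound 2 (`CC(C)(C)CCN/C(=C\[N+](=O)[O-])Nc1cccnc1`) reads 2000 nM while compound 3 (`O=[N+]([O-])/C=C(/Nc1cccnc1)NC1CCCCC1`) reads 3160 nM and so sits level with compound 2, far from compound 1. Among the compounds with values here, the next compound, compound 4 (`CC(C)N/C(=C\[N+](=O)[O-])Nc1cccnc1`), keeps the shared core but carries isopropyl in place of cyclohexyl on an amine nitrogen as its only difference from compound 3.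

Within the data shown here, three measured steps bear on this change, all at the same nitrogen. Two are large, a 63-fold higher number from compound 1 to compound 2 (1.80 log units; beyond the scatter) and a 100-fold higher number from compound 1 to compound 3 (2.00 log units; beyond the scatter) and both start from the 1,2,2-trimethylpropyl group of compound 1, which compound 4 does not carry. The third, a 1.6-fold higher number from compound 2 to compound 3 (0.20 log units; within the scatter) shows two different groups reading alike, within the scatter. Among the measured compounds shown here, no measured compound carries isopropyl, so the range must stay wide. Expected here is a 1.3-fold higher number from compound 3 to compound 4 (0.10 log units; within the scatter) and thus no step beyond the scatter. The estimated value for compound 4 is 4000 nM (expected range 1000 nM to 13000 nM).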

Compound 4, half-maximal inhibitory concentration: 31600 nM
Estimate against measurement, compound 4: 7.9-fold (0.90 log units) below, and the stated range ends below it.
By their numbers in this assay, from the lowest: compound 1; then compounds 2 and 3 (each within the scatter of the next); then compound 4.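

The change from cyclohexyl to isopropyl on this amine nitrogen is not neutral: in this assay it gives a 10-fold higher number from compound 3 to compound 4 (1.00 log units; beyond the scatter). Isopropyl also stands apart from 3,3-dimethylbutyl, with a 16-fold higher number from compound 2 to compound 4 (1.20 log units; beyond the scatter), so this position, where two different groups had read alike, does separate the groups placed on it. Methyl in place of tert-butyl on the saturated chain carbon bound to the amine nitrogen gives a 1000-fold higher number from compound 1 to compound 4 (3.00 log units; beyond the scatter), the widest step in the set, and compound 4 is the weakest inhibitor of the four.

Nothing available explains why these groups differ so widely. From the compounds shown here alone, whether cyclopentyl or a longer branched chain on this nitrogen would read nearer compound 1 or compound 4 stays open.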